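This account rests on a few compounds, and the source may have more. Where it says the series, first, only, none or still open, it means among the compounds named here.

Compound 1 `O=C(CCC(=O)c1ccc(F)cc1)NCCCO`: in a functional assay on the whole organism with Mus musculus as the target, in the maximal electroshock model (on this read-out higher numbers stand for an effect only at larger amounts of compound and lower numbers for an effect already at smaller amounts), compound 1 gives > 400 mg/kg, which is a limit of the assay and not a number.
Compound 2 `O=C(CCC(=O)c1ccc(Cl)cc1)NCCCO`: in this assay compound 2 gives > 300 mg/kg, again a limit of the assay.
Compound 3 `COc1ccc(C(=O)CCC(=O)NCCCO)cc1`: in this assay compound 3 gives > 600 mg/kg, once more a limit of the assay.

Compound 3 therefore stands nowhere in particular among the three: all that is known of it is a limit, and the two other values shown are limits as well. The step from compound 1 to compound 3 reads a step that the two limits leave unreadable from compound 1 to compound 3, and the step from compound 2 to compound 3 reads a step that the two limits leave unreadable from compound 2 to compound 3; between compound 1 and compound 2 the step reads a step that the two limits leave unreadable from compound 1 to compound 2. None of these carries a size, as the limit of > 300 mg/kg in this assay, at which 1 of the 3 values shown sits, the limit of > 400 mg/kg in this assay, at which 1 of the 3 values shown sits, and the limit of > 600 mg/kg in this assay, at which 1 of the 3 values shown sits, show.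

Compound 4 `Cc1ccc(C(=O)CCC(=O)NCCCO)cc1` is the next one to be measured in this assay. The change from compound 3 to compound 4 is methyl in place of methoxy on an aromatic carbon, in words methyl in place of methoxy on an aromatic carbon. Within the data shown here, no measured step bears on this exchange with a readable size, since every step that ends at compound 3 is left open by the limits. What the series does show is that three differently substituted members of the shared core all reach only a limit, so compound 4 is expected to behave alike, with an expected step of an at least 1.2-fold lower number from compound 3 to compound 4 (0.07 log units; that floor lies within the scatter) that is most likely no step beyond the scatter. Compound 4 is accordingly estimated at 500 mg/kg, with a range from 200 mg/kg to 1500 mg/kg, and the measurement is more likely than not to be reported again as a limit rather than as a number.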

Compound 4, dose for half-maximal effect: > 300 mg/kg
Compound 4: a limit, no number; the forecaster's own chance of this, stated with the estimate: 80%; the middle value is on the limit's open side.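

In this assay compound 4 gives > 300 mg/kg, which is a limit of the assay and not a number. Among these compounds, with compound 1, compound 2 and compound 3 also known only as limits, no step to compound 4 can be read. The compounds shown leave open what dose for half-maximal effect any of the four has, and how the four rank.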